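This account rests on a few compounds, and the source may have more. Where it says the series, first, only, none or still open, it means among the compounds named here.

Compound 1 `CCCCCCCC/C=C\CCCCCCC(=O)c1nc2ccccc2o1` is a long unsaturated chain ending in a carbonyl that carries a fused two-ring heteroaromatic group. For the measured compounds named here, in an assay on isolated protein for inhibition of Fatty-acid amide hydrolase 1 (Homo sapiens) (a lower number here means a stronger inhibitor, a higher number a weaker inhibitor), compound 1 gives 370 nM, the higher of the two numbers so far. Going by the values given here, its only measured neighbour is compound 2 `CCCCCCCC/C=C\CCCCCCC(=O)c1ncco1`, which keeps the chain and the carbonyl but carries a single five-membered ring in place of the fused system; in this assay compound 2 gives 17 nM, and the step of a 22-fold lower number from compound 1 to compound 2 (1.34 log units; beyond the scatter) shows how strongly that change moved the number.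

Compound 3 `CCCCCCCC/C=C\CCCCCCC(=O)c1nc2cccc(C)c2o1` keeps the fused system of compound 1 and adds only a small group: methyl in place of hydrogen on an aromatic carbon, on an aromatic carbon of the six-membered ring, ortho to a fused ring. Among the compounds with values here, no measured pair speaks to such an addition. The step from compound 1 to compound 2 concerns removal of the whole six-membered ring, not a substituent on it, so it offers little guidance beyond showing that this part of the molecule matters. With nothing to set a direction, the expected step of a 1.1-fold higher number from compound 1 to compound 3 (0.03 log units; within the scatter) is small and within the scatter. Compound 3 is therefore estimated at 400 nM, within a range from 150 nM to 1100 nM.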

Compound 3, inhibition constant: 13000 nM
For compound 3 the middle estimate is 33-fold (1.51 log units) below the measured one; the whole stated range lies below it.
By their numbers in this assay, from the lowest: compound 2; then compound 1; then compound 3.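

In this assay, the step of a 35-fold higher number from compound 1 to compound 3 (1.55 log units; beyond the scatter) shows that one added methyl, a single heavy atom in place of hydrogen, is enough to make the number much higher at this carbon of the six-membered ring, ortho to a fused ring. For the compounds shown here, the earlier pair, with its step of a 22-fold lower number from compound 1 to compound 2 (1.34 log units; beyond the scatter), showed only that replacing the whole fused system with the single five-membered ring changes the number, whereas this result shows that the fused system also responds strongly to a very small change at one carbon. Nothing measured here says why this methyl has so large an effect.

Only one substituted compound of this kind is shown, so it remains open whether the rise belongs to this particular carbon or would follow a methyl on another carbon of the six-membered ring. As far as these compounds go, it also remains open whether fluorine, a methoxy group or an amine at this same carbon would raise the number as far as methyl does.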